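A Further Stereoisomer at the Limit of Cytotoxicity Testing

A few compounds are considered here, and "the series" means these few. Any claim that something is new, unique, unknown or untested is made for them only; others in the source may bear on it.

Two stereoisomers open the account: compound 1 `COC(=O)[C@@]1(CC=C(C)C)C[C@H](CC=C(C)C)C(C)(C)[C@H](C(=O)C(C)C)C1=O` and compound 2 `COC(=O)[C@]1(CC=C(C)C)C[C@H](CC=C(C)C)C(C)(C)[C@H](C(=O)C(C)C)C1=O`. In a functional assay on A549 cells (Homo sapiens) for cytotoxicity, read by CellTiter-Glo, with a stated time of 5 days (on this read-out higher numbers stand for weaker inhibition and lower numbers for stronger inhibition), compound 1 gives > 10000 nM, which is a limit and not a number. Compound 2 gives > 10000 nM, which is also a limit. Compound 2 therefore has no numerical position, and the measured picture is the limit of > 10000 nM in this assay, at which 2 of the 2 values shown sit.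

Among the measured compounds shown here, the only measured step that bears on the next comparison is a step that the two limits leave unreadable from compound 1 to compound 2. It concerns (the fact that compounds 1 and 2 differ only in the configuration as drawn), so it offers a precedent for a change of configuration but no size.

Compound 3 `COC(=O)[C@]1(CC=C(C)C)C[C@H](CC=C(C)C)C(C)(C)[C@@H](C(=O)C(C)C)C1=O` is a further stereoisomer of compound 2: the two compounds have the same atoms and bonds and differ only in configuration as drawn: 1 of 3 stereo elements differ; a stereocentre at a saturated ring carbon is drawn R in compound 2 and S in compound 3. No atoms leave or enter. With only limits to go on, no step beyond the scatter is expected in this assay, and no direction can be assigned. The expected step is a step that the limit leaves unreadable from compound 2 to compound 3. Compound 3 is estimated at 15000 nM, with an expected range of 4000 nM to 40000 nM. A further limit is the most likely report.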

Compound 3, half-maximal inhibitory concentration: > 10000 nM
Compound 3 was reported as a limit; the forecaster's own chance of this, stated with the estimate: 75%; the middle value is on the limit's open side.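

In this assay compound 3 gives > 10000 nM, which is a limit and not a number. No step among compound 1, compound 2 and compound 3 can be read, and the picture remains a single one: the limit of > 10000 nM in this assay, at which 3 of the 3 values shown sit.

The compounds shown leave open whether any of these changes of configuration alters the read-out at all.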